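From pyridin-3-yl to morpholin-4-yl on the carbonyl carbon

The compounds below may be only part of what the source reports. "The series", "measured", "known", "first", "only" and "open" are said of these compounds alone.

In a functional assay (aorta) with Rattus norvegicus as the target (on this read-out lower numbers stand for an effect already at smaller amounts and higher numbers for an effect only at larger amounts of compound), compound 2 (`C/N=C(/NC)Nc1nc(-c2ccc(OC)cc2)c(-c2ccc(OC)cc2)s1`) gives 2.4 uM and compound 3 (`COc1ccc(-c2nc(CNC(=O)c3cccnc3)sc2-c2ccc(OC)cc2)cc1`) gives 8.2 uM as its read-out, so compound 3 holds the higher of these two numbers. Compound 1 (`COc1ccc(-c2nc(/N=C(\N)NC3CCCCC3)sc2-c2ccc(OC)cc2)cc1`) gives > 100 uM as a limit of this assay and not as a number.

The next change leads to compound 4 (`COc1ccc(-c2nc(CNC(=O)N3CCOCC3)sc2-c2ccc(OC)cc2)cc1`), with morpholin-4-yl in place of pyridin-3-yl on a carbonyl carbon. Among the measured compounds shown here, no measured step isolates this change. The modest step of a 3.4-fold higher number from compound 2 to compound 3 (0.53 log units; beyond the scatter) and the large steps of an at least 41-fold lower number from compound 1 to compound 2 (1.61 log units; beyond the scatter) and an at least 12-fold lower number from compound 1 to compound 3 (1.08 log units; beyond the scatter) all replace a whole group on an aromatic carbon, so they bear on it only indirectly. They do show that this read-out responds strongly to changes in that group.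

For the measured compounds named here, the one weak guide is that the only non-aromatic ring among the measured groups sits in compound 1, with its limit of > 100 uM in this read-out. A modest move towards a higher number is therefore expected, not a large one. For compound 4 the expected step is a 2.4-fold higher number from compound 3 to compound 4 (0.39 log units; beyond the scatter) on this estimate. In this assay the estimated value for compound 4 is 20 uM within an expected range from 5 uM to 70 uM as the working figure.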

Compound 4, concentration for half-maximal effect: 12 uM
Beside the measured number, compound 4's estimate is 1.7-fold (0.22 log units) above it; measured number inside the range.
By their numbers in this assay, from the lowest: compound 2; then compounds 3 and 4 (each within the scatter of the next). At a limit, above all of these: compound 1.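

Among the compounds shown here, with the change isolated for the first time in this assay, the replacement on a carbonyl carbon whose other neighbour is an amide-type nitrogen gives a 1.5-fold higher number from compound 3 to compound 4 (0.17 log units; within the scatter), so this read-out does not separate morpholin-4-yl from pyridin-3-yl at this place. A non-aromatic ring here is therefore compatible with a measurable read-out, and the larger differences remain with the whole group on the aromatic carbon, with a 5.0-fold higher number from compound 2 to compound 4 (0.70 log units; beyond the scatter) and an at least 8.3-fold lower number from compound 1 to compound 4 (0.92 log units; beyond the scatter). The value of compound 1 is a limit of the assay and not a number, so the second of these steps gives only a bound: the limit of > 100 uM in this assay, at which 1 of the 4 values shown sits.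

The compounds shown leave open whether a carbon-only ring such as cyclohexyl, or an open-chain amine such as diethylamino, on the same carbonyl carbon would also stay within the scatter of compound 3. They also do not show which part of the group on the aromatic carbon accounts for the gap to compound 2, given that this group differs there as a whole.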